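Swapping Pentylcarbonyl for (4-Carboxyphenyl)sulfonyl on Compound 2

The compounds below may be only part of what the source reports. "The series", "measured", "known", "first", "only" and "open" are said of these compounds alone.

Three compounds have been measured in a functional assay for inhibition, with Homo sapiens as the target; a higher number here means a weaker inhibitor, a lower number a stronger inhibitor:

Compound 1, `O=C(O)CCNC(=O)c1ccc2c(c1)C(=O)N(CCC1CCNCC1)C2`, gives 27 nM.
Compound 2, `CCCCCC(=O)N[C@@H](CNC(=O)c1ccc2c(c1)C(=O)N(CCC1CCNCC1)C2)C(=O)O`, gives 13 nM.
Compound 3, `O=C(NCc1ccccc1)N[C@@H](CNC(=O)c1ccc2c(c1)C(=O)N(CCC1CCNCC1)C2)C(=O)O`, gives 10 nM.

Compound 2 holds the second highest of these three numbers. Its nearest neighbour is compound 3, since the step of a 1.3-fold lower number from compound 2 to compound 3 (0.11 log units; within the scatter) stays within the usual scatter; its furthest is compound 1, from which the step of a 2.1-fold lower number from compound 1 to compound 2 (0.32 log units; beyond the scatter) is a modest one.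

The next compound, compound 4, `O=C(O)c1ccc(S(=O)(=O)N[C@@H](CNC(=O)c2ccc3c(c2)C(=O)N(CCC2CCNCC2)C3)C(=O)O)cc1`, differs from compound 2 in a single place:

(4-carboxyphenyl)sulfonyl in place of pentylcarbonyl on an amine nitrogen

Two measured steps speak to this. The steps of a 2.1-fold lower number from compound 1 to compound 2 (0.32 log units; beyond the scatter) and a 2.7-fold lower number from compound 1 to compound 3 (0.43 log units; beyond the scatter) show that attaching either a (pentylcarbonyl)amino or a (benzylcarbamoyl)amino group to the bare chain carbon of compound 1 lowers the number by a modest amount. The step of a 1.3-fold lower number from compound 2 to compound 3 (0.11 log units; within the scatter) then shows that exchanging pentyl for benzylamino on the carbonyl carbon makes no difference beyond the scatter. Since the group on that nitrogen changed once without effect, the move to (4-carboxyphenyl)sulfonyl is expected to give no step beyond the scatter, a 1.1-fold lower number from compound 2 to compound 4 (0.03 log units; within the scatter). Compound 4 is therefore estimated at 12 nM, within a range from 5 nM to 30 nM.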

Compound 4, half-maximal inhibitory concentration: 7 nM
For compound 4 the middle estimate is 1.7-fold (0.23 log units) above the measured one, and the stated range covers the measured number.
By their numbers in this assay, from the lowest: compounds 4, 3 and 2 (each within the scatter of the next); then compound 1.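

In this assay, replacing the carbonyl link on this amine nitrogen with a sulfonyl link, and adding a six-membered aromatic ring and a carboxylic acid, gives no change beyond the scatter (a 1.9-fold lower number from compound 2 to compound 4 (0.27 log units; within the scatter)). Exchanging the benzylcarbamoyl group for the same sulfonyl group also stays within the scatter (a 1.4-fold lower number from compound 3 to compound 4 (0.15 log units; within the scatter)). The earlier compounds showed only a swap on the carbonyl carbon, whereas this series now shows that the amine nitrogen can carry a group of 12 heavy atoms, against 7 in pentylcarbonyl, without moving the number beyond the scatter, though no measured evidence bears on why this is so.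

The compounds shown leave open whether the carboxylic acid on the aromatic ring contributes anything, which a plain phenylsulfonyl group or an amine at that ring place would help to test. They also leave open how a much shorter group, such as acetyl, or a longer chain on the carbonyl carbon would compare with pentylcarbonyl on this nitrogen.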